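This account rests on a few compounds, and the source may have more. Where it says the series, first, only, none or still open, it means among the compounds named here.

Working notes on the series. Going by the values given here, the shared core carries a chloromethyl-benzyl group, and the three compounds measured so far differ in where that group sits and in the chloro count on the core. Compound 1 `ClCc1ccccc1Cn1cnc2c(Cl)ncnc21` was tested in a functional assay on MCF7 cells (Homo sapiens) for cytotoxicity, read by sulforhodamine B assay, with a stated time of 48 h; on this read-out lower numbers stand for higher toxicity in this test and higher numbers for lower toxicity in this test; for compound 1 the result is a limit of the assay, > 100000 nM. For compound 3 `ClCc1ccc(Cn2cnc3c(Cl)nc(Cl)nc32)cc1` the result in this assay is likewise a limit, > 100000 nM. Among the compounds with values here, compound 2 `ClCc1cccc(Cn2cnc3ncnc(Cl)c32)c1` gives the only number in this assay, 39000 nM, and stands alone against (the limit of > 100000 nM in this assay, at which 2 of the 3 values shown sit). Compound 4 `ClCc1cccc(Cn2cnc3nc(Cl)nc(Cl)c32)c1` has not been measured in this assay. It differs from compound 2 by chloro in place of hydrogen on an aromatic carbon. Within the data shown here, no measured step shows this change, so the expected step of a 1.3-fold higher number from compound 2 to compound 4 (0.11 log units; within the scatter) is none beyond the scatter. Compound 4 is estimated at 50000 nM, within 15000 nM to 150000 nM.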

Compound 4, concentration lethal to 50% of the cells: > 100000 nM
Compound 4 gave a limit, no number (the forecaster's own chance of this, stated with the estimate: 40%); middle value at least 2.0-fold (0.30 log units) from the limit.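

Chloro in place of hydrogen on an aromatic carbon, between two ring nitrogen atoms, is the first change in the series that can be read as a single step, and in this assay it gives an at least 2.5-fold higher number from compound 2 to compound 4 (0.40 log units; beyond the scatter). Compound 4 carries a limit and not a number, so the full size of this step stays unread. Going by these compounds alone, compound 2 remains the only compound with a number: the limit of > 100000 nM in this assay, at which 3 of the 4 values shown sit. On these data alone, whether an amine or a methoxy group at this same position would give a number in this assay stays open.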